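A few compounds are considered here, and "the series" means these few. Any claim that something is new, unique, unknown or untested is made for them only; others in the source may bear on it.

Compound 1 `CC(C)COc1ccc(CN(Cc2ccncc2)S(=O)(=O)c2cccc(F)c2)cc1` gives > 200000 nM
Compound 2 `Cc1ccc(-n2c(SCC(=O)N3CCN(c4ccccc4)CC3)nnc2-c2ccncc2)cc1Cl` gives 21100 nM

In an ADME assay on U2OS cells (Homo sapiens) for cytotoxicity, with a stated time of 96 h (a higher number here means that more compound is tolerated, a lower number that less compound is tolerated), compound 1 has only a limit, > 200000 nM, and not a number. Compound 2 has a different structure and gives a true reading, 21100 nM, so it offers no direct guide to the change considered here.

Compound 3 `COc1ccc(S(=O)(=O)N(Cc2ccncc2)Cc2ccc(OCC(C)C)cc2)cc1OC` keeps the core of compound 1 but has 3,4-dimethoxyphenyl in place of 3-fluorophenyl on a sulfonyl sulfur. Among the measured compounds shown here, no measured pair shows what a change of this kind does in this assay. A modest step toward less compound tolerated is expected, though one no larger than the scatter would be no surprise. The expected step is an at least 1.5-fold lower number from compound 1 to compound 3 (0.18 log units; that floor lies within the scatter), and compound 3 may also end up reported only as a limit. For compound 3 the estimated value is 130000 nM, with an expected range of 40000 nM to 200000 nM.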

Compound 3, half-maximal cytotoxic concentration: 21700 nM
Compound 3: the middle estimate sits 6.0-fold (0.78 log units) above what was measured; measured number outside the range, below it.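

In this assay, the swap of 3-fluorophenyl for 3,4-dimethoxyphenyl on a sulfonyl sulfur gives an at least 9.2-fold lower number from compound 1 to compound 3 (0.96 log units; beyond the scatter). Among the compounds shown here, this is the first sign that the group held by this sulfonyl sulfur can matter, and it turns a reading without an end point into a true number, as compound 3 gives 21700 nM. The full size of the step remains unknown because compound 1 is reported only as a limit: the limit of > 200000 nM in this assay, at which 1 of the 3 values shown sits.

The compounds shown leave open whether the step follows the loss of the fluorine or the arrival of the two methoxy groups, and whether a single methoxy group would have a similar effect. They also do not show how a phenyl ring bearing an amine or a carboxylic acid would fare on this sulfonyl sulfur.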